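Methoxymethyl to ethoxymethyl: what compound 4 might show

The compounds below may be only part of what the source reports. "The series", "measured", "known", "first", "only" and "open" are said of these compounds alone.

Compound 1, `Cc1coc(-c2ccc3c(c2O)CCCC3(C)C)c1C(=O)O`, gives 24.7 uM in a functional assay on MDA-MB-231 cells (Homo sapiens) for cytotoxicity, read by sulforhodamine B assay, with a stated time of 3 days; a higher number here means that more compound is needed for the effect, a lower number that less compound is needed.
Compound 2, `COCc1c(C)coc1-c1ccc2c(c1OC)CCCC2(C)C`, gives 47.8 uM in this assay.
Compound 3, `CCOc1c(-c2occ(C)c2CO)ccc2c1CCCC2(C)C`, gives 39.8 uM in this assay.

Compound 2 holds the highest of the three numbers, but the gaps to compound 3 and to compound 1 both fall within the usual scatter, so none of the three can be set apart. Compound 4, `CCOCc1c(C)coc1-c1ccc2c(c1OC)CCCC2(C)C`, differs from compound 2 by methyl in place of hydrogen on a saturated chain carbon bound to an oxygen on a saturated carbon. For the measured compounds named here, no step between measured compounds bears on this change, so in this assay the step from compound 2 is expected to stay within the scatter, with no clear direction. Compound 4 is therefore estimated at 45 uM, within 20 uM to 110 uM, an expected step of a 1.1-fold lower number from compound 2 to compound 4 (0.03 log units; within the scatter).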

Compound 4, concentration for half-maximal effect: 42.7 uM
Compound 4: middle estimate off by 1.1-fold (0.02 log units), on the high side; the range from low to high includes it.
By their numbers in this assay, from the lowest: compounds 1, 3, 4 and 2 (each within the scatter of the next).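

The change from methoxymethyl to ethoxymethyl comes with a 1.1-fold lower number from compound 2 to compound 4 (0.05 log units; within the scatter) in this assay and gives the first directly readable single change among these compounds. At this position, one added methyl on the saturated chain carbon bound to the oxygen does not separate compound 4 from compound 2, and no direction can be assigned to the step. Nothing available offers an explanation for this result. The compounds shown leave open whether a longer chain, such as propoxymethyl, or an amine at this position would give a step beyond the scatter.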